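Compound 1 to compound 3: chloro replaced by 2-hydroxyethoxy

This account rests on a few compounds, and the source may have more. Where it says the series, first, only, none or still open, it means among the compounds named here.

In a functional assay on SK-MEL-28 cells (Homo sapiens) for cytotoxicity, read by CCK-8 assay, with a stated time of 24 h (a higher number here means a weaker inhibitor, a lower number a stronger inhibitor), compound 1 (`COc1ccccc1Oc1c(N)nc(-c2cccc(Cl)c2)nc1Cl`) gives 19400 nM, the higher of the two numbers, and compound 2 (`COc1ccccc1Oc1c(N)nc(-c2ccc(Br)cc2)nc1Cl`) gives 14 nM. Compound 3 (`COc1ccccc1Oc1c(N)nc(-c2cccc(Cl)c2)nc1OCCO`) keeps the 3-chlorophenyl group of compound 1 and carries 2-hydroxyethoxy in place of chloro on an aromatic carbon. For the measured compounds named here, the only measured step, a 1400-fold lower number from compound 1 to compound 2 (3.14 log units; beyond the scatter), exchanges the 3-chlorophenyl group instead, so it sets no direct size for this change. Going by the values given here, no measured step touches the chloro. A small move toward a weaker number is therefore expected, with wide uncertainty. The estimated step is a 1.3-fold higher number from compound 1 to compound 3 (0.11 log units; within the scatter). For compound 3 the expected value is 25000 nM, with an estimated range of 5000 nM to 100000 nM.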

Compound 3, half-maximal inhibitory concentration: 4170 nM
Beside the measured number, compound 3's estimate is 6.0-fold (0.78 log units) above it, outside the stated range (below it).
By their numbers in this assay, from the lowest: compound 2; then compound 3; then compound 1.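

In this assay, 2-hydroxyethoxy in place of chloro gives a 4.7-fold lower number from compound 1 to compound 3 (0.67 log units; beyond the scatter), so this position, next to the ring nitrogen, accepts a chain with a hydrogen-bond donor and the chloro is not needed for activity with the 3-chlorophenyl group present. The gain remains modest beside a 1400-fold lower number from compound 1 to compound 2 (3.14 log units; beyond the scatter). No evidence is available on what lies behind the shift. Going by these compounds, whether the change carries over to the 4-bromophenyl group of compound 2 remains open. Also open, on these data alone, is how an amine, a carboxylic acid or a longer chain at this position would compare with 2-hydroxyethoxy.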